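This account rests on a few compounds, and the source may have more. Where it says the series, first, only, none or still open, it means among the compounds named here.

Series notes on an assay on THP-1 cells for displacement of a labelled ligand from C-C chemokine receptor type 1 (Homo sapiens); on this read-out higher numbers stand for weaker inhibition and lower numbers for stronger inhibition.

Of the compounds shown here, three of the shared core carry numbers so far. Compound 2 `CC(C)[C@@H](NC(=O)c1cccc(F)c1)C(=O)N1CCC(c2ccc(Cl)cc2)CC1` is the compound with the lowest number of the three: in this assay compound 2 gives 24 nM. Compound 1 `CC(C)C(NS(=O)(=O)Cc1ccccc1)C(=O)N1CCC(c2ccc(Cl)cc2)CC1`, which carries a sulfonamide in place of the amide, gives 303 nM in this assay, a difference from compound 2 that lies beyond the scatter. Compound 3 `CC(C)C(NC(=O)c1ccccc1)C(=O)N1CCN(c2ccc(Cl)cc2)CC1`, which carries an unsubstituted phenyl on the carbonyl and a differently built ring next to the second carbonyl, gives 525 nM in this assay, the highest number of the three and again beyond the scatter from compound 2.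

Compound 4 `CC(C)[C@@H](NC(=O)CC1CC1)C(=O)N1CCC(c2ccc(Cl)cc2)CC1` has not yet been measured. It differs from compound 2 in one place: cyclopropylmethyl in place of 3-fluorophenyl on a carbonyl carbon. Among the compounds with values here, no measured pair separates this change on its own, so its size can only be estimated. Because compound 1 gives 303 nM and compound 3 gives 525 nM, every departure so far from the pattern of compound 2 has moved the number upward, and a move of that direction and a moderate size, beyond the scatter, is expected here as well. Compound 4 is estimated at 150 nM, with a range from 40 nM to 600 nM. The expected step, a 6.3-fold higher number from compound 2 to compound 4 (0.80 log units; beyond the scatter), thus points toward weaker inhibition.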

Compound 4, half-maximal inhibitory concentration: 46 nM
The estimate for compound 4 lay 3.3-fold (0.51 log units) above the measured number; the range from low to high includes it.
By their numbers in this assay, from the lowest: compounds 2 and 4 (each within the scatter of the next); then compounds 1 and 3 (each within the scatter of the next).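

In this assay the series gains its first one-place comparison, and the step reads a 1.9-fold higher number from compound 2 to compound 4 (0.28 log units; within the scatter) on a carbonyl carbon whose other neighbour is an amide-type nitrogen. At this place, therefore, the 3-fluorophenyl and the cyclopropylmethyl cannot be told apart by this read-out, although the first brings a six-membered aromatic ring of carbon only with 7 heavy atoms and the second a three-membered non-aromatic ring of carbon only with 4 heavy atoms, so an aromatic ring on this carbonyl carbon is not needed for a number at this level in the two compounds compared. No measurement at hand beyond these numbers explains why the two groups read alike.

As far as these compounds go, whether this tolerance reaches groups of another kind at the same place, such as a chain ending in an amine, a carboxylic acid or a longer alkyl chain, remains open. The effects of the sulfonamide in compound 1 and of the two differences in compound 3 also remain open, since neither compound has a one-place partner among those shown.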